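A few compounds are considered here, and "the series" means these few. Any claim that something is new, unique, unknown or untested is made for them only; others in the source may bear on it.

Measured so far:
- compound 1, `O=C(CCc1ccc(Oc2ccccc2)cc1)c1ncc(I)o1`: 10 nM
- compound 2, `COC(=O)c1ccc(-c2cnc(C(=O)CCc3ccc(Oc4ccccc4)cc3)o2)nc1`: 54 nM

In an assay for inhibition of Fatty-acid amide hydrolase 1 (Rattus norvegicus) (a lower number here means a stronger inhibitor, a higher number a weaker inhibitor), compound 1 gives 10 nM, and compound 2 gives 54 nM. Of the two numbers, compound 2 stands at the highest; its nearest neighbour is compound 1, and the gap between them, a 5.4-fold higher number from compound 1 to compound 2 (0.73 log units; beyond the scatter), lies beyond the scatter. Compound 3, `N#Cc1cnc(C(=O)CCc2ccc(Oc3ccccc3)cc2)o1`, has not yet been measured. It differs from compound 2 in one place: cyano in place of 5-(methoxycarbonyl)pyridin-2-yl on an aromatic carbon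

For the measured compounds named here, the only measured step that bears on this change is the one from compound 1 to compound 2, where a large group took the place of iodo and the number rose by a 5.4-fold higher number from compound 1 to compound 2 (0.73 log units; beyond the scatter). Compound 3 goes the other way, exchanging that large group for a small one. He therefore expects a lower number in this assay for compound 3, with a step of about a 3.6-fold lower number from compound 2 to compound 3 (0.56 log units; beyond the scatter), of a size similar to the one seen between compound 1 and compound 2 but in the opposite direction. His estimate for compound 3 is 15 nM, within a range from 5 nM to 45 nM.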

Compound 3, inhibition constant: 0.8 nM
Beside the measured number, compound 3's estimate is 19-fold (1.27 log units) above it, outside the stated range (below it).
By their numbers in this assay, from the lowest: compound 3; then compound 1; then compound 2.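

In this assay, replacing 5-(methoxycarbonyl)pyridin-2-yl with cyano gives a 68-fold lower number from compound 2 to compound 3 (1.83 log units; beyond the scatter), far more than the earlier exchange of iodo for that large group had suggested this position could yield. Replacing iodo with cyano gives a 13-fold lower number from compound 1 to compound 3 (1.10 log units; beyond the scatter), so the position can go well below the number seen with iodo, and the earlier step had shown only that one large group gave a higher number than iodo. No measurement bearing on the reason for these differences is available.

Because the leaving group carries a six-membered aromatic ring and a methoxycarbonyl group together, the compounds shown cannot separate the part played by each, and a simple methoxycarbonyl group or an unsubstituted pyridine ring at this position would be needed to do so. Going by these compounds, it also remains open whether the low number is particular to cyano or would be shared by other groups on this aromatic carbon, such as a carboxylic acid, an amine or a methyl group.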